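The source may hold more compounds than are shown below. What is called first, only, known or untested is meant among the compounds shown, and "the series" means these compounds.

Measured compounds and their numbers in an ADME assay on microsomes from liver (Homo sapiens) for metabolic stability, with a stated time of 10 min; on this read-out higher numbers stand for a more stable compound and lower numbers for a less stable compound:

Compound 1, `CC(C)(C)NC(=O)NCCS(=O)(=O)NC(=O)c1ccc(Nc2nc(NC3(c4ccc(Cl)cc4)CC3)nc(OCC(F)(F)F)n2)cc1`: 96%
Compound 2, `O=C(NS(=O)(=O)CCNC(=O)C1CC1)c1ccc(Nc2nc(NC3(c4ccc(Cl)cc4)CC3)nc(OCC(F)(F)F)n2)cc1`: 90%
Compound 3, `CC(C)OC(=O)NCCS(=O)(=O)NC(=O)c1ccc(Nc2nc(NC3(c4ccc(Cl)cc4)CC3)nc(OCC(F)(F)F)n2)cc1`: 100%

All three share one core and differ only in the group on a carbonyl carbon at the end of the side chain. On the numbers alone compound 3 has the highest reading of the three, yet the steps to it are small: a number 4 percentage points higher from compound 1 to compound 3 (within the scatter) and a number 10 percentage points higher from compound 2 to compound 3 (within the scatter) both lie within the scatter of this assay, so the three compounds cannot be told apart with confidence. The third step, a number 6 percentage points lower from compound 1 to compound 2 (within the scatter), is likewise within the scatter.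

Compound 4, `CC(=O)NCCS(=O)(=O)NC(=O)c1ccc(Nc2nc(NC3(c4ccc(Cl)cc4)CC3)nc(OCC(F)(F)F)n2)cc1`, is the next variation at the same place: methyl in place of isopropoxy on a carbonyl carbon. Every measured step at this carbonyl carbon, whether an amino, a cyclopropyl or an isopropoxy group sat there, stayed within the scatter, and nothing in these data points to a different outcome for a methyl group. The expected step is therefore none beyond the scatter, a number 4 percentage points lower from compound 3 to compound 4 (within the scatter). Compound 4 is thus estimated at 96%, with a range from 85% to 100%.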

Compound 4, percent of the compound remaining: 95%
Estimate against measurement, compound 4: 1 percentage points above; measured number inside the range.
By their numbers in this assay, from the lowest: compounds 2, 4, 1 and 3 (each within the scatter of the next).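

In this assay, the change from isopropoxy, with 4 heavy atoms, to methyl, with 1 heavy atom, stays within the scatter, and so does every other step to this small group: a number 5 percentage points lower from compound 3 to compound 4 (within the scatter), a number 5 percentage points higher from compound 2 to compound 4 (within the scatter) and a number 1 percentage points lower from compound 1 to compound 4 (within the scatter). Across these four compounds, then, no group on this carbonyl carbon stands apart from the others, and even a single carbon here gives a reading that cannot be told apart from theirs. Nothing available explains why these readings stay so close together.

From the compounds shown here alone, it remains open whether an amine or a carboxylic acid on this carbonyl carbon, or a longer chain there, would also stay within the scatter. Going by these compounds, the effect of changes elsewhere on the shared core also remains open.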